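This account rests on a few compounds, and the source may have more. Where it says the series, first, only, none or still open, it means among the compounds named here.

Measured in an ADME assay on Vero cells (Chlorocebus sabaeus) for cytotoxicity, read by MTT assay, with a stated time of 72 h; on this read-out lower numbers stand for higher toxicity in this test and higher numbers for lower toxicity in this test:
- compound 1 `CCOC(=O)c1c(-c2ccc(OC)cc2)oc2ccc(OCCCCCCN3C(=O)/C(=N\OC)c4cc(F)ccc43)cc12`: 16 ug/mL
- compound 2 `CCOC(=O)c1c(-c2ccc(OC)cc2)oc2ccc(OCCCCCCN3C(=O)/C(=N\OC)c4ccccc43)cc12`: 32 ug/mL
- compound 3 `CCO/N=C1\C(=O)N(CCCCOc2ccc3oc(-c4ccc(OC)cc4)c(C(=O)OCC)c3c2)c2ccc(F)cc21`: 32 ug/mL

Compound 2 stands level with compound 3 at the digits shown, and the only measured step that reaches it, a 2.0-fold higher number from compound 1 to compound 2 (0.30 log units; within the scatter), is hydrogen in place of fluoro on an aromatic carbon. Compound 4 `CCOC(=O)c1c(-c2ccc(OC)cc2)oc2ccc(OCCCCCCN3C(=O)/C(=N\NC(N)=S)c4ccccc43)cc12` departs from compound 2 in one place: a group of 4 heavy atoms (1 carbon, 2 nitrogen, 1 sulfur; no ring) in place of a group of 2 heavy atoms (1 carbon, 1 oxygen; no ring), on a double-bonded nitrogen, on a double-bonded nitrogen. Within the data shown here, no measured step touches that nitrogen, so the data give no direction for this change, and in this assay no shift beyond the scatter is expected. The expected step is no change at the digits printed from compound 2 to compound 4 (within the scatter). With so little to go on, the range stays wide. Compound 4 is estimated at 32 ug/mL, with an expected range of 8 ug/mL to 128 ug/mL.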

Compound 4, half-maximal cytotoxic concentration: 8 ug/mL
For compound 4 the middle estimate is 4.0-fold (0.60 log units) above the measured one, within the range that was stated.
By their numbers in this assay, from the lowest: compounds 4, 1, 2 and 3 (each within the scatter of the next, the first and the last beyond it).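

In this assay, the change on this double-bonded nitrogen gives a step beyond the scatter, a 4.0-fold lower number from compound 2 to compound 4 (0.60 log units; beyond the scatter), whereas the earlier step on an aromatic carbon stayed within it, a 2.0-fold higher number from compound 1 to compound 2 (0.30 log units; within the scatter). The group on this nitrogen therefore bears on the number: replacing methoxy with the group of 4 heavy atoms goes with higher toxicity in this test. Nothing available accounts for this shift.

As far as these compounds go, it remains open whether a hydroxy group or an amine on this nitrogen would shift the number in the same way. From the compounds shown here alone, it is also open whether the step would hold with fluoro on the aromatic carbon, as in compound 1.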